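Thiazole for pyrazole on the macrocyclic core: tolerance outlook

The source may hold more compounds than are shown below. What is called first, only, known or untested is meant among the compounds shown, and "the series" means these compounds.

Within the data shown here, compound 2 `CCn1cc(-c2cc(OCC[C@@H]3NC(=O)N(C)CCCC/C=C\[C@@H]4C[C@@]4(C(=O)NS(=O)(=O)C4(C)CC4)NC3=O)c3ccc(OC)c(C)c3n2)cn1` is the only member of the set that returns a number in an ADME assay on cells (Homo sapiens) for activation; a lower number here means that less compound is tolerated, a higher number that more compound is tolerated: compound 2 gives 36700 nM. The two remaining values are not numbers but limits of the assay. Compound 1 `COc1ccc2c(OCC[C@@H]3NC(=O)N(C)CCCC/C=C\[C@@H]4C[C@@]4(C(=O)NS(=O)(=O)C4(C#N)CC4)NC3=O)cc(-c3nc(C(C)C)cs3)nc2c1Cl`, which carries the 4-isopropyl-1,3-thiazol-2-yl group, reaches only the limit of > 75000 nM. Compound 3 `COc1ccc2c(OCC[C@@H]3NC(=O)N(C)CCCC/C=C\[C@@H]4C[C@@]4(C(=O)NS(=O)(=O)C4CC4)NC3=O)cc(-c3nc(C(C)C)cs3)nc2c1F`, with the same group and a fluorine on the shared core, likewise stops at the limit of > 75000 nM. Among the measured compounds shown here, the one firm foothold is therefore (the limit of > 75000 nM in this assay, at which 2 of the 3 values shown sit); no step between two measured compounds that differ in a single place is available.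

Compound 4 `COc1ccc2c(OCC[C@@H]3NC(=O)N(C)CCCC/C=C\[C@@H]4C[C@@]4(C(=O)NS(=O)(=O)C4(C)CC4)NC3=O)cc(-c3nc(C(C)C)cs3)nc2c1C` is not yet measured. Against compound 2 the change is 4-isopropyl-1,3-thiazol-2-yl in place of 1-ethyl-1H-pyrazol-4-yl on an aromatic carbon. The two measured compounds that bear 4-isopropyl-1,3-thiazol-2-yl sit at the limit, while compound 2 with 1-ethyl-1H-pyrazol-4-yl sits below it, so the expected step in this assay from compound 2 to compound 4 is upward, probably beyond the usual scatter, as a 1.6-fold higher number from compound 2 to compound 4 (0.21 log units; within the scatter). Compound 4 is accordingly estimated at 60000 nM, with a range from 25000 nM to 150000 nM; a result that is again only a limit would not be surprising.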

Compound 4, half-maximal cytotoxic concentration: 31900 nM
Compound 4: the middle estimate sits 1.9-fold (0.27 log units) above what was measured; measured number inside the range.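

Among these compounds, on an aromatic carbon next to the ring nitrogen, 4-isopropyl-1,3-thiazol-2-yl in place of 1-ethyl-1H-pyrazol-4-yl provides the first single-place comparison, and in this assay it gives a 1.2-fold lower number from compound 2 to compound 4 (0.06 log units; within the scatter), so this assay does not tell the two groups apart on this core. Compound 4 carries the thiazole group and returns 31900 nM. This group alone therefore does not bring a compound to the limit. Compounds 1 and 3 carry the same group but differ from compound 4 in more than one place, so what places them at the limit remains unassigned: the limit of > 75000 nM in this assay, at which 2 of the 4 values shown sit.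

The chlorine and nitrile of compound 1 and the fluorine of compound 3 each appear only alongside a second difference from compound 4, so none of them can be tied to the limit on its own. Also open is how the number in this assay would respond to a morpholine or a carboxylic acid on the same aromatic carbon, since both heteroaryl groups shown are five-membered aromatic rings with the same counts of donors and acceptors.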